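Furan-linked diamines: trifluoromethoxy to methoxy on the aryl ring

A few compounds are considered here, and "the series" means these few. Any claim that something is new, unique, unknown or untested is made for them only; others in the source may bear on it.

Two compounds of this series have numbers in an assay on cells for inhibition of protein arginine N-methyltransferase 1 (Homo sapiens), read by scintillation counting, with stated times of 15 min and 60 min, tested at 9 uM; on this read-out lower numbers stand for less inhibition and higher numbers for more inhibition at the one concentration tested (going by the name of the read-out). Compound 1 `CNCCN(C)Cc1ccc(-c2ccc(OC)cc2)o1` gives 38% in this assay. Compound 2 `CN(CCN)Cc1ccc(-c2ccc(OC(F)(F)F)cc2)o1` gives 25% in this assay, the lowest of the two numbers shown; its nearest neighbour on the numbers is compound 1, which sits higher by a gap beyond the scatter. Going by the values given here, compound 1 and compound 2 differ in more than one place, so no single step between them is given; their two values are all that can be said.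

Compound 3 `COc1ccc(-c2ccc(CN(C)CCN)o2)cc1` has not been measured in this assay. It differs from compound 2 as follows: methyl in place of trifluoromethyl on an oxygen on an aromatic ring. The change sits on the oxygen on the aromatic ring, and one bond further out reads trifluoromethoxy to methoxy.

Among the compounds with values here, no measured step covers this change. Compound 1 carries the same methoxy group and gives 38% in this assay, so a small upward step is expected, possibly still within the scatter, estimated as a number 8 percentage points higher from compound 2 to compound 3 (within the scatter). Compound 3 is expected to give about 33% in this assay, within a range of 15% to 50%.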

Compound 3, a percentage reported as inhibition, at one concentration (the size of the read-out at that concentration, not a potency): 25%
Beside the measured number, compound 3's estimate is 8 percentage points above it, within the range that was stated.
By their numbers in this assay, from the lowest: compounds 2 and 3 (each within the scatter of the next); then compound 1.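

In this assay, methyl in place of trifluoromethyl on an oxygen on an aromatic ring gives no change at the digits printed from compound 2 to compound 3 (within the scatter) and so leaves the read-out unmoved for this pair, which means this position shows no sensitivity to the trifluoromethoxy to methoxy change at the one concentration tested. The single-place step that does register lies on the amine nitrogen, where hydrogen in place of methyl gives a number 13 percentage points lower from compound 1 to compound 3 (beyond the scatter) and is a modest change beyond the scatter. The difference between compound 1 and compound 2 can now be read through compound 3 and follows the amine nitrogen rather than the oxygen substituent, though this rests on these three compounds alone. No measurement shown offers a reason for either step.

Going by these compounds, it remains open whether the amine nitrogen accepts anything larger than methyl, such as an ethyl group or a longer chain, and whether the step seen there would hold with trifluoromethoxy on the aromatic ring. Also open, on these data alone, is whether the insensitivity at the oxygen extends to a free hydroxyl or an ethoxy group in place of methoxy.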